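Inverted stereocentre in the 2,3-dihydroxypropyl chain

This account rests on a few compounds, and the source may have more. Where it says the series, first, only, none or still open, it means among the compounds named here.

Measured compounds in a functional assay on MDA-MB-231 cells (Homo sapiens) for cytotoxicity, read by MTT assay, with a stated time of 72 h; on this read-out lower numbers stand for stronger inhibition and higher numbers for weaker inhibition:
compound 1 `O=C1c2c[n+]([O-])c3ccccc3c2C(=O)c2c1c1ccccc1n2Cc1cn(C[C@@H](O)CO)nn1` gives 670 nM
compound 2 `O=C1c2c[n+]([O-])c3ccccc3c2C(=O)c2c1c1ccccc1n2Cc1cn([C@@H]2C[C@H](O)[C@@H](CO)O2)nn1` gives 130 nM
compound 3 `CN1CCN(CCCn2c3c(c4ccccc42)C(=O)c2c[n+]([O-])c4ccccc4c2C3=O)CC1` gives 390 nM

Compound 1 stands at the highest of the three numbers. Compound 3 is nearest to it, and that gap, a 1.7-fold lower number from compound 1 to compound 3 (0.24 log units; within the scatter), stays within the scatter, so the two are not ordered. Compound 2 is furthest, with a 5.2-fold lower number from compound 1 to compound 2 (0.71 log units; beyond the scatter), a modest but real step that comes with a 4-hydroxy-5-(hydroxymethyl)oxolan-2-yl in place of the 2,3-dihydroxypropyl on the aromatic nitrogen.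

Compound 4 `O=C1c2c[n+]([O-])c3ccccc3c2C(=O)c2c1c1ccccc1n2Cc1cn(C[C@H](O)CO)nn1` is the next compound of the series. It differs from compound 1 as follows: the two compounds have the same atoms and bonds and differ only in configuration as drawn: 1 of 1 stereo elements differ; a stereocentre at a saturated chain carbon is drawn R in compound 1 and S in compound 4.

Neither measured step bears directly on this change. Both involve an exchange of one group for another, whereas here nothing leaves and nothing enters; only the drawn configuration of the one stereocentre on the 2,3-dihydroxypropyl chain is inverted. Among the measured compounds shown here, there is no pair of enantiomers among the measured compounds to show how this read-out responds to such an inversion. For the measured compounds named here, with no comparable step to lean on, the expectation is a step of no change at the digits printed from compound 1 to compound 4 (within the scatter), that is, no change beyond the scatter, in either direction. Compound 4 is therefore estimated at 670 nM, within the range 300 nM to 1500 nM.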

Compound 4, half-maximal inhibitory concentration: 1310 nM
Estimate against measurement, compound 4: 2.0-fold (0.29 log units) below; the range from low to high includes it.
By their numbers in this assay, from the lowest: compound 2; then compounds 3, 1 and 4 (each within the scatter of the next, the first and the last beyond it).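

In this assay, among the compounds shown here, the inversion gives the first reading of configuration at this saturated chain carbon on the 2,3-dihydroxypropyl chain: a 2.0-fold higher number from compound 1 to compound 4 (0.29 log units; within the scatter), so the R and S forms as drawn are not ordered. The S form does stand apart from the 2-(4-methylpiperazin-1-yl)ethyl compound, with a 3.4-fold higher number from compound 3 to compound 4 (0.53 log units; beyond the scatter), whereas the R form does not, with a 1.7-fold lower number from compound 1 to compound 3 (0.24 log units; within the scatter), and against the 4-hydroxy-5-(hydroxymethyl)oxolan-2-yl compound the S form shows a 10-fold higher number from compound 2 to compound 4 (1.00 log units; beyond the scatter). Those differing outcomes rest on two values that lie within the scatter of each other, so they give no firm sign that configuration matters here, and the comparison between the two forms isolates that single variable: the fact that compounds 1 and 4 differ only in the configuration as drawn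

Still open, from the compounds shown here alone, is whether an amine or a carboxylic acid in place of a hydroxyl on this chain, or a longer chain such as 3,4-dihydroxybutyl, would stay in the same range of this assay. Also open is how inverting a stereocentre on the 4-hydroxy-5-(hydroxymethyl)oxolan-2-yl group would read, given that the only inversion shown is on the 2,3-dihydroxypropyl chain.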